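Ethyl in Place of Methyl on the Ring Nitrogen

The source may hold more compounds than are shown below. What is called first, only, known or untested is meant among the compounds shown, and "the series" means these compounds.

Working notes on the series: compounds 1, 2 and 3 measured, compound 4 not yet.

Compound 1 `CN1C(=O)N(C)C2C1NC(=S)N2/N=C/C=C/c1ccccc1` reaches only the limit of a functional assay on MCF7 cells (Homo sapiens) for inhibition, read by MTT assay, with a stated time of 72 h (on this read-out lower numbers stand for stronger inhibition and higher numbers for weaker inhibition), with > 100000 nM. Compound 2 `CN1C(=O)N(c2ccccc2)C2NC(=S)N(/N=C/C=C/c3ccccc3)C21` likewise gives no number in this assay but the limit > 100000 nM. The step that the two limits leave unreadable from compound 1 to compound 2 is thus unreadable; both values sit at the limit of > 100000 nM in this assay, at which 2 of the 3 values shown sit. Going by the values given here, compound 3 `COc1ccccc1/C=C/C=N/N1C(=S)NC2C1N(C)C(=O)N2c1ccccc1` is the one member with a real number in this assay, namely 260 nM, and the step of an at least 380-fold lower number from compound 2 to compound 3 (2.58 log units; beyond the scatter) is large. That step concerns a methoxy on an aromatic carbon and leaves the alkyl group on the ring nitrogen untouched.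

Compound 4 `CCN1C(=O)N(c2ccccc2)C2NC(=S)N(/N=C/C=C/c3ccccc3)C21` differs from compound 2 by methyl in place of hydrogen on a saturated chain carbon bound to an amide-type nitrogen in a ring; read one bond further out, the change is methyl to ethyl. Among the compounds with values here, no measured pair in this set alters that group, so the only anchor is the limit reported for compound 2 in this assay. Compound 4 is therefore expected to stay close to where compound 2 stands, the expected step being a number no higher from compound 2 to compound 4 (the limit leaves the size open). The estimate for compound 4 in this assay is 100000 nM, expected to fall between 25000 nM and 400000 nM, with a repeated limit the most probable outcome.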

Compound 4, half-maximal inhibitory concentration: 2250 nM
Beside the measured number, compound 4's estimate is 44-fold (1.65 log units) above it; measured number outside the range, below it.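

Until now the alkyl group on the nitrogen had not been varied, and compound 2 offered only a limit. In this assay, methyl in place of hydrogen on a saturated chain carbon bound to an amide-type nitrogen in a ring gives an at least 44-fold lower number from compound 2 to compound 4 (1.64 log units; beyond the scatter), so this position responds to the change of methyl to ethyl. The value of compound 2 is a limit and not a number, which leaves the true size of this step open: the limit of > 100000 nM in this assay, at which 2 of the 4 values shown sit.

Compound 2 now has two single changes that each lead to a measured number, the methoxy on an aromatic carbon and this methyl, so the aromatic carbon is not the only place in the series where such a step appears.

Going by these compounds, whether a longer chain such as propyl or butyl lowers the number further, or a hydroxyl or an amine at the end of the chain keeps the step, remains open. Also open, on these data alone, is how the ethyl and the methoxy behave when both stand on the shared core.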